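Series notes: nitro in place of trifluoromethyl, compound 2 to compound 3

The compounds below may be only part of what the source reports. "The series", "measured", "known", "first", "only" and "open" are said of these compounds alone.

Compound 2 `CCCS(=O)(=O)Nc1ccc(F)c(C(=O)c2n[nH]c3ncc(-c4cccc(C(F)(F)F)c4)cc23)c1F` gives 57% in an assay for binding affinity to dual specificity mitogen-activated protein kinase kinase 4 (Homo sapiens), read by KINOMEscan, tested at 100 nM (a lower number here means a stronger effect, a higher number a weaker effect of the compound at the concentration tested), the highest of the two numbers recorded; compound 1 `CCCS(=O)(=O)Nc1ccc(F)c(C(=O)c2n[nH]c3ncc(-c4ccc(N(C)C)cc4)cc23)c1F` gives 2.5%. For the measured compounds named here, the only measured step, a number 54.5 percentage points higher from compound 1 to compound 2 (beyond the scatter), replaces the entire group on that aromatic carbon and does not reach the change at hand. Compound 3 `CCCS(=O)(=O)Nc1ccc(F)c(C(=O)c2n[nH]c3ncc(-c4cccc([N+](=O)[O-])c4)cc23)c1F` differs from compound 2 by nitro in place of trifluoromethyl on an aromatic carbon. Going by the values given here, no measured pair covers nitro in place of trifluoromethyl, so no step beyond the scatter is expected, a number 2 percentage points lower from compound 2 to compound 3 (within the scatter). Compound 3 is therefore estimated at 55%, with a wide range from 25% to 85%.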

Compound 3, a percentage reported as activity, at one concentration (the size of the read-out at that concentration, not a potency): 15%
Estimate against measurement, compound 3: 40 percentage points above; measured number below the stated range.
By their numbers in this assay, from the lowest: compound 1; then compound 3; then compound 2.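

At this position, the group on the aromatic carbon alone changes the read-out in this assay: with the 3-substituted phenyl kept, nitro in place of trifluoromethyl gives a number 42 percentage points lower from compound 2 to compound 3 (beyond the scatter). A 3-substituted phenyl can therefore bind much more strongly than compound 2 suggested, although 3-nitrophenyl still falls short of 4-(dimethylamino)phenyl, with a number 12.5 percentage points higher from compound 1 to compound 3 (beyond the scatter). Nothing measured here explains the change.

Still open, going by these compounds, is how an amine or a nitrile on the same aromatic carbon would read. The compounds shown also do not separate the dimethylamino group from its placement on the phenyl ring.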